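Allyl-substituted phenol triazoles: aryl group on the triazole nitrogen

The compounds below may be only part of what the source reports. "The series", "measured", "known", "first", "only" and "open" are said of these compounds alone.

Measured compounds, inhibition of HL-60 growth:
- compound 1 `C=CCc1ccc(OCc2cn(-c3ccc(C#N)cc3)nn2)c(O)c1` gives 20.8% in a functional assay on HL-60 cells (Homo sapiens) for inhibition, read by MTT assay, with a stated time of 72 h, tested at 30 uM; on this read-out higher numbers stand for more inhibition of growth at the one concentration tested and lower numbers for less inhibition of growth
- compound 2 `C=CCc1ccc(OCc2cn(-c3ccc(OC)cc3)nn2)c(O)c1` gives 21.3% in this assay
- compound 3 `C=CCc1ccc(OCc2cn(-c3cccc(C#N)c3)nn2)c(O)c1` gives 22.5% in this assay

Compound 2 stands second of the three numbers in this assay, with compound 1 nearest and compound 3 furthest, and both neighbours lie within the scatter of it. Neither exchanging the group on the aromatic ring, a number 0.5 percentage points higher from compound 1 to compound 2 (within the scatter), nor moving the nitrile to the other position, a number 1.7 percentage points higher from compound 1 to compound 3 (within the scatter), nor the combined change a number 1.2 percentage points higher from compound 2 to compound 3 (within the scatter) shifts the read-out beyond the scatter. The shared core with an aryl group on the triazole nitrogen therefore shows one flat level in this set.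

Compound 4 `C=CCc1ccc(OCc2cn(-c3ccc(C(=O)c4ccccc4)cc3)nn2)c(O)c1` is not yet measured. It differs from compound 2 by benzoyl in place of methoxy on an aromatic carbon. Among the compounds with values here, no measured step replaces a small substituent by a group of this size; the nearest comparison, methoxy for cyano, a number 0.5 percentage points higher from compound 1 to compound 2 (within the scatter), is within the scatter. Since every step seen so far stays within the scatter, no step beyond the scatter is expected in this assay from compound 2 to compound 4 either, a number 2.7 percentage points higher from compound 2 to compound 4 (within the scatter), with wide uncertainty because the change is larger than any tested. Compound 4 is estimated at 24%, within 12% to 40%.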

Compound 4, percent growth inhibition at one concentration: 38.3%
Estimate against measurement, compound 4: 14.3 percentage points below; low and high end bracket the measured number.
By their numbers in this assay, from the lowest: compounds 1, 2 and 3 (each within the scatter of the next); then compound 4.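

Working from the printed numbers, the aromatic carbon para to a large group is not a silent position in this assay: benzoyl in place of methoxy gives a number 17 percentage points higher from compound 2 to compound 4 (beyond the scatter), and benzoyl in place of cyano gives a number 17.5 percentage points higher from compound 1 to compound 4 (beyond the scatter). The flat level of compounds 1, 2 and 3 therefore does not hold for every group at this place, and the read-out moves once benzoyl enters, with its 8 heavy atoms and one six-membered aromatic ring against the 2 heavy atoms and no ring of methoxy. Nothing at hand bears on why the number rises, and this single change does not separate the contribution of the added ring from that of the carbonyl.

Still open, going by these compounds, is whether the carbonyl is needed at all, a question that a phenyl, benzyl or phenoxy group at the same place would address. Also open, on these data alone, is how an amine or a carboxylic acid on the outer ring of the benzoyl group would read in this assay, and whether benzoyl at the other ring position seen with the nitrile of compound 3 would give the same rise.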